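A few compounds are considered here, and "the series" means these few. Any claim that something is new, unique, unknown or untested is made for them only; others in the source may bear on it.

Compound 1 `Cc1ccoc1C(=O)Nc1cccc(-c2nc3ncccc3o2)c1` and compound 2 `O=C(Nc1ccc(F)c(-c2nc3ncccc3o2)c1)c1cnco1` share a common core. In a physicochemical assay for solubility, read by nephelometry, in phosphate buffer, measured as kinetic solubility, at pH 2 (on this read-out lower numbers stand for lower solubility and higher numbers for higher solubility), compound 1 gives 6.3 ug/mL, and in this assay compound 2 gives 6.3 ug/mL; at the digits shown the two values are level, within the scatter, so compound 1 stands at the same point as its nearest neighbour. Compound 3 `Cc1ccc(NC(=O)c2occc2C)cc1-c1nc2ncccc2o1` has not yet been measured in this assay. It differs from compound 1 by methyl in place of hydrogen on an aromatic carbon. For the measured compounds named here, no pair of measured compounds covers this kind of change. For compound 3 a small downward step in this assay is expected, or none beyond the scatter. The expected value for compound 3 is 4 ug/mL, with a range from 1.5 ug/mL to 10 ug/mL. This corresponds to an expected step of a 1.6-fold lower number from compound 1 to compound 3 (0.20 log units; within the scatter).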

Compound 3, solubility: 1.6 ug/mL
Estimate against measurement, compound 3: 2.5-fold (0.40 log units) above; the range from low to high includes it.
By their numbers in this assay, from the lowest: compound 3; then compounds 1 and 2 (each within the scatter of the next).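

In this assay, methyl in place of hydrogen on an aromatic carbon, ortho to one group of 9 heavy atoms and para to another, gives a 3.9-fold lower number from compound 1 to compound 3 (0.60 log units; beyond the scatter), so this position is not neutral to the read-out. For the compounds shown here, this is the first pair covering this change, and it rests on a single step. Nothing measured here bears on the reason for the drop.

Still open, going by these compounds, is whether the same step appears in other compounds. Also open, on these data alone, is whether an amine, a carboxylic acid or a longer chain at this position moves the number the same way.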